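Pyrazolopyridine amides: cytotoxicity limit, trifluorophenyl to pyrimidinyl

This account rests on a few compounds, and the source may have more. Where it says the series, first, only, none or still open, it means among the compounds named here.

Compound 1 `CC(C)n1ncc2c(C(=O)Nc3ccncn3)cc(-c3ccsc3)nc21`: > 200000 nM.
Compound 2 `CC(C)n1ncc2c(C(=O)Nc3c(F)cc(F)cc3F)cc(-c3cccs3)nc21`: > 200000 nM.

Both values come from an ADME assay on LLC-MK2 cells (Macaca mulatta) for cytotoxicity, read by spectrophotometry and crystal violet staining, with a stated time of 4 days; on this read-out lower numbers stand for higher toxicity in this test and higher numbers for lower toxicity in this test. For compound 2 the value is a limit of the assay, not a number. The same holds for compound 1, so the limit of > 200000 nM in this assay, at which 2 of the 2 values shown sit, is all the evidence there is, and compound 2 cannot be placed above or below any other compound.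

Compound 3 `CC(C)n1ncc2c(C(=O)Nc3ccncn3)cc(-c3cccs3)nc21` has not yet been measured. It differs from compound 2 in one place: pyrimidin-4-yl in place of 2,4,6-trifluorophenyl on an amide-type nitrogen. Compound 3 also shares with compound 1 the pyrimidin-4-yl on the amide-type nitrogen.

With nothing measured beyond the limit, no step beyond the scatter is expected in this assay; the expected step is a number no higher from compound 2 to compound 3 (the limit leaves the size open). Compound 3 is accordingly expected to give 200000 nM, with a range of 100000 nM to 400000 nM, most likely again reported only as a limit.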

Compound 3, half-maximal cytotoxic concentration: 50000 nM
Compound 3: middle estimate off by 4.0-fold (0.60 log units), on the high side, and the stated range ends above it.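

In this assay, the group on the amide-type nitrogen now shows an effect that the two limit values could not: with thiophen-2-yl held, pyrimidin-4-yl in place of 2,4,6-trifluorophenyl gives an at least 4.0-fold lower number from compound 2 to compound 3 (0.60 log units; beyond the scatter). The thiophene attachment matters as well: with pyrimidin-4-yl held, thiophen-2-yl in place of thiophen-3-yl on an aromatic carbon gives an at least 4.0-fold lower number from compound 1 to compound 3 (0.60 log units; beyond the scatter). Both sizes are lower bounds, because compound 1 and compound 2 each carry a limit, not a number: the limit of > 200000 nM in this assay, at which 2 of the 3 values shown sit.

Going by these compounds alone, open is whether the lower number in this assay follows either group alone or only the two together, as compound 3 is the one compound here that combines them. Also open, as far as these compounds go, is how a phenyl bearing a carboxylic acid or an amine on the amide-type nitrogen would read in this assay.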